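A few compounds are considered here, and "the series" means these few. Any claim that something is new, unique, unknown or untested is made for them only; others in the source may bear on it.

Measured compounds:
compound 1 `COc1ccccc1/C=C(/Sc1ccc(C)cc1)C(=O)c1ccc(Cl)cc1`, 25000 nM
compound 2 `COc1ccccc1/C=C(/SCc1ccc(C)cc1)C(=O)c1ccc(Cl)cc1`, 10000 nM
compound 3 `COc1ccccc1/C=C(/SCc1ccc(Cl)c(Cl)c1)C(=O)c1ccc(Cl)cc1`, 10000 nM

In a functional assay on DU-145 cells (Homo sapiens) for inhibition, read by trypan blue exclusion, with a stated time of 96 h (on this read-out lower numbers stand for stronger inhibition of growth and higher numbers for weaker inhibition of growth), compound 2 gives 10000 nM, level with compound 3 at the digits shown and together with it the lowest of the three numbers; compound 1 sits furthest away, with a 2.5-fold lower number from compound 1 to compound 2 (0.40 log units; beyond the scatter). Compound 4 `Cc1ccc(CS/C(=C/c2cccc(Cl)c2Cl)C(=O)c2ccc(Cl)cc2)cc1` differs from compound 2 by one change: 2,3-dichlorophenyl in place of 2-methoxyphenyl on a double-bonded chain carbon bound to a double-bonded chain carbon. Going by the values given here, none of the measured steps touches this position; a 2.5-fold lower number from compound 1 to compound 2 (0.40 log units; beyond the scatter), a 2.5-fold lower number from compound 1 to compound 3 (0.40 log units; beyond the scatter) and no change at the digits printed from compound 2 to compound 3 (within the scatter) all concern the group on the sulfur, so they give no direct guide. Lacking any step at the double-bonded chain carbon, a step of no change at the digits printed from compound 2 to compound 4 (within the scatter) in this assay is expected, that is, nothing beyond the scatter. Compound 4 is therefore estimated at 10000 nM, within 3000 nM to 30000 nM.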

Compound 4, concentration for 50% growth inhibition: 25000 nM
Compound 4: middle estimate off by 2.5-fold (0.40 log units), on the low side, within the range that was stated.
By their numbers in this assay, from the lowest: compounds 2 and 3 (each within the scatter of the next); then compounds 1 and 4 (each within the scatter of the next).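

In this assay the 2,3-dichlorophenyl in place of 2-methoxyphenyl gives a 2.5-fold higher number from compound 2 to compound 4 (0.40 log units; beyond the scatter) and so weaker inhibition of growth. The other steps concern only the group on the sulfur, so this one shows that the number also responds to a change on the double-bonded chain carbon bound to a double-bonded chain carbon. Nothing available explains this step.

A single exchange cannot separate the departure of the methoxy group from the arrival of the two chlorines. Going by these compounds, how an unsubstituted phenyl or a 2-aminophenyl would stand at this place remains open.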